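A Substituted Nitrogen: Compound 1 to Compound 4

The source may report more compounds than this note shows. Statements on the series, on what has been measured and on what is new or still open speak of the compounds shown alone.

Values in a functional assay on CCRF-CEM cells (Homo sapiens) for cytotoxicity, in the absence of a further agent (on this read-out higher numbers stand for weaker inhibition and lower numbers for stronger inhibition), so far:
Compound 1 (`Nc1nc(N)c(CCCNc2cc(F)ccc2[N+](=O)[O-])c(O)n1`) gives > 100000 nM as a limit
Compound 2 (`Nc1nc(N)c(CCCNc2cc(F)cc(F)c2[N+](=O)[O-])c(O)n1`) gives 97000 nM as a number
Compound 3 (`Nc1nc(N)c(CCCN(Cc2ccc(NC(CCC(=O)O)C(=O)O)cc2)c2ccc([N+](=O)[O-])c(F)c2F)c(O)n1`) gives > 100000 nM as a limit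

Compound 1 stands at the limit of > 100000 nM in this assay, at which 2 of the 3 values shown sit, and so has a limit and no number. Compound 4 (`COC(=O)c1ccc(CN(CCCc2c(N)nc(N)nc2O)c2cc(F)ccc2[N+](=O)[O-])cc1`) differs from compound 1 by 4-(methoxycarbonyl)benzyl in place of hydrogen on a nitrogen on an aromatic ring and thus carries 4-(methoxycarbonyl)benzyl in place of hydrogen on a nitrogen on an aromatic ring. Within the data shown here, the one measured step, an at least 1.0-fold lower number from compound 1 to compound 2 (0.01 log units; that floor lies within the scatter), is a fluoro change elsewhere and says little about this nitrogen. Compound 3 also carries a substituent on that nitrogen, and its > 100000 nM is again a limit. No step beyond the scatter is therefore firmly expected in this assay, and the expected change is an at least 1.2-fold lower number from compound 1 to compound 4 (0.09 log units; that floor lies within the scatter) in size. Compound 4 is estimated at 80000 nM, with an expected range from 25000 nM to 200000 nM in this measurement.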

Compound 4, half-maximal inhibitory concentration: 55000 nM
Compound 4: the middle estimate sits 1.5-fold (0.16 log units) above what was measured; low and high end bracket the measured number.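

In this assay, the nitrogen on the aromatic ring accepts 4-(methoxycarbonyl)benzyl in place of hydrogen, and compound 4 gives a number where compound 1 has only a limit. The step reads an at least 1.8-fold lower number from compound 1 to compound 4 (0.25 log units; that floor lies within the scatter), so no firm change can be claimed for this substitution. That step remains a floor, because compound 1 has no number: the limit of > 100000 nM in this assay, at which 2 of the 4 values shown sit.

Going by these compounds, how a plain methyl on this nitrogen would read remains open. So does the effect of a primary amine in place of the methoxycarbonyl on the benzyl ring.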